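The compounds below may be only part of what the source reports. "The series", "measured", "known", "first", "only" and "open" are said of these compounds alone.

Measured so far: compound 1 `CN(C[C@@H]1CCCc2cc(S(=O)(=O)c3cccc(F)c3)ccc21)S(N)(=O)=O`, 3.98 nM in an assay on isolated protein for displacement of a labelled ligand from 5-hydroxytryptamine receptor 6 (Homo sapiens); on this read-out lower numbers stand for stronger inhibition and higher numbers for weaker inhibition; compound 2 `COCCNC[C@@H]1CCCc2cc(S(=O)(=O)c3cccc(F)c3)ccc21`, 0.251 nM.

Compound 2 holds the lower of the two numbers, and the step of a 16-fold lower number from compound 1 to compound 2 (1.20 log units; beyond the scatter) lies beyond the scatter. Compound 3 `CNC(=O)NC[C@@H]1CCCc2cc(S(=O)(=O)c3cccc(F)c3)ccc21` differs from compound 2 by methylcarbamoyl in place of 2-methoxyethyl on an amine nitrogen. Within the data shown here, only that one measured step bears on it, and it ran the other way, putting (2-methoxyethyl)amino in place of methyl(sulfamoyl)amino. Compound 3 gives the 2-methoxyethyl up again, so a step toward higher numbers is expected, about a 10-fold higher number from compound 2 to compound 3 (1.00 log units; beyond the scatter). Compound 3 is therefore estimated at 2.5 nM, between 0.6 nM and 10 nM.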

Compound 3, inhibition constant: 0.398 nM
Compound 3: the middle estimate sits 6.3-fold (0.80 log units) above what was measured; the measured number lies below the stated range.
By their numbers in this assay, from the lowest: compounds 2 and 3 (each within the scatter of the next); then compound 1.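

In this assay, methylcarbamoyl in place of 2-methoxyethyl on the amine nitrogen gives a 1.6-fold higher number from compound 2 to compound 3 (0.20 log units; within the scatter), which lies within the scatter, even though the entering group carries a hydrogen-bond donor that the leaving group lacks. Measured against the methyl(sulfamoyl)amino group, (methylcarbamoyl)amino gives a 10-fold lower number from compound 1 to compound 3 (1.00 log units; beyond the scatter), so the gain over compound 1 is not confined to (2-methoxyethyl)amino. Nothing in the data given accounts for these numbers.

The compounds shown leave open how a plain unsubstituted amine, a longer chain or a carboxylic acid on this nitrogen would read out.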